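Taking the Ethyl Group Off a Weak Growth Inhibitor

The source may report more compounds than this note shows. Statements on the series, on what has been measured and on what is new or still open speak of the compounds shown alone.

In a functional assay on MCF7 cells (Homo sapiens) for inhibition, read by CCK-8 assay, with a stated time of 48 h (on this read-out higher numbers stand for weaker inhibition of growth and lower numbers for stronger inhibition of growth), compound 1 `Cc1ccccc1Nc1nc(Nc2ccccn2)ncc1Cl` gives 31400 nM. Compound 2 `CCN1CCN(c2ccc(Nc3ncc(Cl)c(Nc4ccccc4C)n3)nc2)CC1` gives > 100000 nM, which is a limit of the assay and not a number. Compound 2 therefore has no exact place on the scale, and only the weak end of this assay can be given for it.

Compound 3 `Cc1ccccc1Nc1nc(Nc2ccc(N3CCNCC3)cn2)ncc1Cl` has hydrogen in place of ethyl on an amine nitrogen in a ring. The 4-ethylpiperazin-1-yl group thus becomes piperazin-1-yl.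

Among the compounds with values here, only one measured step bears on this change: an at least 3.1-fold higher number from compound 1 to compound 2 (0.50 log units; beyond the scatter). That step added the whole 4-ethylpiperazin-1-yl group and moved the read-out toward weaker inhibition. The new change removes only the ethyl and leaves the ring in place, so little of that step is likely to be undone. Within the data shown here, no measured step shows what the ethyl alone contributes, so this remains uncertain.

A modest move toward a lower number is expected, estimated as an at least 1.6-fold lower number from compound 2 to compound 3 (0.22 log units; that floor lies within the scatter). For compound 3 the estimate is 60000 nM, with an expected range from 15000 nM to 200000 nM.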

Compound 3, concentration for 50% growth inhibition: 3410 nM
The estimate for compound 3 lay 18-fold (1.25 log units) above the measured number; the measured number lies below the stated range.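

In this assay, the ethyl on the amine nitrogen of the six-membered ring turns out to matter a great deal: hydrogen in its place gives an at least 29-fold lower number from compound 2 to compound 3 (1.46 log units; beyond the scatter). The ring itself does not weaken growth inhibition, since piperazin-1-yl in place of hydrogen on an aromatic carbon gives a 9.2-fold lower number from compound 1 to compound 3 (0.96 log units; beyond the scatter), while 4-ethylpiperazin-1-yl in that same place gave an at least 3.1-fold higher number from compound 1 to compound 2 (0.50 log units; beyond the scatter), a change in the opposite direction. Compound 2 stands at a limit of the assay and not at a number, so the step from it gives only a floor and the full effect of the ethyl cannot be sized: the limit of > 100000 nM in this assay, at which 1 of the 3 values shown sits.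

The compounds shown leave open whether ethyl is special or whether any carbon group on that nitrogen would have the same effect, a question that a methyl, a longer chain such as propyl, or an acetyl group there could help to answer. They also leave open whether the gain over compound 1 needs the piperazine ring at all, or whether an open-chain amine in the same place would give it too.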